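Bromoacetamide Added to an Aniline Chalcone-Triazole

The compounds below may be only part of what the source reports. "The series", "measured", "known", "first", "only" and "open" are said of these compounds alone.

Three compounds share a core in which an aromatic ring linked to a triazole is joined through a carbonyl-bearing double bond. Compound 1 `O=C(CN1CCN(c2ccccc2)CC1)Nc1ccc(C(=O)/C=C/c2cn(Cc3ccc(Br)cc3)nn2)cc1` carries a piperazinyl-acetamide and, in a functional assay on A549 cells (Homo sapiens) for inhibition, read by MTT assay (a lower number here means a stronger inhibitor, a higher number a weaker inhibitor), gives 42100 nM. Compound 2 `CCCCCCCCn1cc(/C=C/C(=O)c2ccc(NC(=O)CBr)cc2)nn1` bears an octyl chain on the triazole together with a bromoacetamide, and in this assay compound 2 gives 11600 nM. Compound 3 `Nc1ccc(C(=O)/C=C/c2cn(Cc3ccc(Br)cc3)nn2)cc1` has a free amine and gives 15800 nM in this assay, the second highest of the three numbers; it sits within the scatter of compound 2, while compound 1 gives a number beyond the scatter above it.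

Compound 4 `O=C(CBr)Nc1ccc(C(=O)/C=C/c2cn(Cc3ccc(Br)cc3)nn2)cc1` arises from compound 3 by (bromomethyl)carbonyl in place of hydrogen on a nitrogen on an aromatic ring. Going by the values given here, no measured pair shows this exact change alone. Compound 4 is expected to give a somewhat lower number than compound 3, because compound 2 gives 11600 nM while carrying the same bromoacetamide on the same aromatic nitrogen. The expected step of a 1.6-fold lower number from compound 3 to compound 4 (0.20 log units; within the scatter) is modest and may not exceed the scatter. Compound 4 is therefore estimated at 10000 nM, with a plausible range from 3500 nM to 30000 nM.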

Compound 4, half-maximal inhibitory concentration: 8670 nM
For compound 4 the middle estimate is 1.2-fold (0.06 log units) above the measured one, within the range that was stated.
By their numbers in this assay, from the lowest: compounds 4, 2 and 3 (each within the scatter of the next); then compound 1.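

In this assay, (bromomethyl)carbonyl in place of hydrogen on the aromatic nitrogen gives a 1.8-fold lower number from compound 3 to compound 4 (0.26 log units; within the scatter), so adding this group to the free amine produces no clear change. Once the bromoacetamide is present, 4-bromophenyl in place of heptyl on the saturated chain carbon bound to an aromatic nitrogen gives a 1.3-fold lower number from compound 2 to compound 4 (0.13 log units; within the scatter), so these two groups cannot be told apart here. The clear difference lies on the acetamide: bromo in place of 4-phenylpiperazin-1-yl on a saturated chain carbon bound to a carbonyl carbon gives a 4.9-fold lower number from compound 1 to compound 4 (0.69 log units; beyond the scatter), showing that the group at this carbon can matter.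

Nothing shown here explains these differences. On these data alone, it remains open whether another group at this carbon, such as chloro or dimethylamino, would give a number closer to that of compound 4 or that of compound 1.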